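Methylsulfanyl in Place of the Trifluoromethyl Ketone

The source may report more compounds than this note shows. Statements on the series, on what has been measured and on what is new or still open speak of the compounds shown alone.

Among the compounds with values here, compound 3 `O=C(CCc1ccc(-c2ccccc2)cc1)c1ncc(C(=O)C(F)(F)F)o1` gives 8 nM in an assay for inhibition of Fatty-acid amide hydrolase 1 (Rattus norvegicus) (on this read-out higher numbers stand for weaker inhibition and lower numbers for stronger inhibition), the highest of the three numbers measured so far. Compound 1 `COC(=O)c1ccc(-c2cnc(C(=O)CCc3ccc(-c4ccccc4)cc3)o2)nc1` gives 2.2 nM in this assay. Compound 2 `CN(C)C(=O)c1cnc(C(=O)CCc2ccc(-c3ccccc3)cc2)o1` gives 3 nM. The two steps ending at compound 3, a 3.6-fold higher number from compound 1 to compound 3 (0.56 log units; beyond the scatter) and a 2.7-fold higher number from compound 2 to compound 3 (0.43 log units; beyond the scatter), were both beyond the scatter, whereas a 1.4-fold higher number from compound 1 to compound 2 (0.13 log units; within the scatter) lay within it. Compound 4 `CSc1cnc(C(=O)CCc2ccc(-c3ccccc3)cc2)o1` differs from compound 3 in one place: methylsulfanyl in place of (trifluoromethyl)carbonyl on an aromatic carbon. Within the data shown here, no measured step introduces methylsulfanyl, so the only guidance is that each change made at that carbon so far moved the number, and that the two steps reaching compound 3 were modest and ran toward weaker inhibition. A modest to moderate step, on balance toward weaker inhibition, is therefore expected. The estimate for compound 4 is 60 nM, within a range of 15 nM to 300 nM. For compound 4 this means an expected step of a 7.5-fold higher number from compound 3 to compound 4 (0.88 log units; beyond the scatter).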

Compound 4, inhibition constant: 3 nM
Estimate against measurement, compound 4: 20-fold (1.30 log units) above, outside the stated range (below it).
By their numbers in this assay, from the lowest: compounds 1, 2 and 4 (each within the scatter of the next); then compound 3.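

In this assay the step is a 2.7-fold lower number from compound 3 to compound 4 (0.43 log units; beyond the scatter), so at this aromatic carbon, next to the ring oxygen, methylsulfanyl with its 2 heavy atoms gives stronger inhibition than the 6 heavy atoms of (trifluoromethyl)carbonyl. Set against the other two groups, the data show no change at the digits printed from compound 2 to compound 4 (within the scatter) and a 1.4-fold higher number from compound 1 to compound 4 (0.13 log units; within the scatter), which leaves methylsulfanyl, dimethylcarbamoyl and 5-(methoxycarbonyl)pyridin-2-yl indistinguishable here, with only compound 3 standing apart. No evidence at hand accounts for this result.

The compounds shown leave open whether an amine, a carboxylic acid or a bare hydrogen at this carbon would keep inhibition at this level. They also leave open what a longer chain on the sulfur, as in ethylsulfanyl, or the methylsulfonyl group would do there.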